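Inverting a ring stereocentre in compound 3: working notes

The source may hold more compounds than are shown below. What is called first, only, known or untested is meant among the compounds shown, and "the series" means these compounds.

compound 1 `NCCCCN(C[C@H]1Cc2ncccc2CN1)[C@H]1CCCc2cccnc21`: 86%
compound 2 `NCCCCN(C[C@@H]1Cc2ncccc2CN1)[C@H]1CCCc2cccnc21`: 75%
compound 3 `CN(C[C@H]1Cc2ncccc2CN1)[C@H]1CCCc2cccnc21`: 53%

In an ADME assay on microsomes from liver (Mus musculus) for metabolic stability, using NADPH, with a stated time of 10 min (on this read-out higher numbers stand for a more stable compound and lower numbers for a less stable compound), compound 3 is the lowest of the three measured compounds (53%), with the other two beyond the scatter above it. Compound 4 `CN(C[C@@H]1Cc2ncccc2CN1)[C@H]1CCCc2cccnc21` is not yet measured, and the change leading to it is the two compounds have the same atoms and bonds and differ only in configuration as drawn: 1 of 2 stereo elements differ; a stereocentre at a saturated ring carbon is drawn R in compound 3 and S in compound 4 and nothing else. The large step (a number 33 percentage points lower from compound 1 to compound 3 (beyond the scatter)) is of another kind and leaves open whether an inversion carries over unchanged to a compound without the 3-aminopropyl group. The guide is the one measured inversion (a number 11 percentage points lower from compound 1 to compound 2 (beyond the scatter)), a modest step that can be put down to the fact that compounds 1 and 2 differ only in the configuration as drawn and that points to a modest fall here too. The expected step in this assay is a fall (a number 10 percentage points lower from compound 3 to compound 4 (within the scatter)). Compound 4 is estimated at 43% within an expected range (28% to 58%).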

Compound 4, percent of the compound remaining: 0%
The estimate for compound 4 lay 43 percentage points above the measured number; measured number below the stated range.
By their numbers in this assay, from the lowest: compound 4; then compound 3; then compound 2; then compound 1.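

In this assay, the inversion at this saturated ring carbon weighs far more without the 3-aminopropyl group, a number 53 percentage points lower from compound 3 to compound 4 (beyond the scatter), than with it, a number 11 percentage points lower from compound 1 to compound 2 (beyond the scatter). Removing 3-aminopropyl likewise weighs more in the S series, a number 75 percentage points lower from compound 2 to compound 4 (beyond the scatter), so the two changes do not add independently: the same change on two cores in this assay, a number 33 percentage points lower (beyond the scatter) from compound 1 to compound 3 and a number 75 percentage points lower (beyond the scatter) from compound 2 to compound 4, 42 percentage points apart, beyond the scatter of two such steps The fall on inversion can be set on configuration alone: the fact that compounds 3 and 4 differ only in the configuration as drawn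

From the compounds shown here alone, whether a shorter chain ending in an amine, or a carboxylic acid in place of that amine, would recover stability with the configuration of compound 4 remains open.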